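A few compounds are considered here, and "the series" means these few. Any claim that something is new, unique, unknown or untested is made for them only; others in the source may bear on it.

Measured in an assay on HEK293 cells for displacement of a labelled ligand from 5-hydroxytryptamine receptor 7 (Rattus norvegicus); on this read-out lower numbers stand for stronger inhibition and higher numbers for weaker inhibition:

Compound 1, `CSc1ccccc1N1CCN(CCCCCC(=O)NCc2ccccc2)CC1`, gives 22 nM
Compound 2, `O=C(CCCCCN1CCN(c2ccccc2-c2ccccc2)CC1)NCc1ccccc1`, gives 0.8 nM
Compound 3, `CSc1ccccc1N1CCN(CCCCCC(=O)NCc2ccc(OS(C)(=O)=O)cc2)CC1`, gives 148 nM

Of these three numbers, compound 3 is the highest, that is, the weakest of the three in this assay. Its nearest neighbour is compound 1, which differs only by one group: a 6.7-fold higher number from compound 1 to compound 3 (0.83 log units; beyond the scatter). Compound 2 is furthest away, and the two values of compound 2 and compound 3 lie far apart.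

The next compound, compound 4, `CS(=O)(=O)Oc1ccc(CNC(=O)CCCCCN2CCN(c3ccccc3-c3ccccc3)CC2)cc1`, is reached from compound 3 by a single change: phenyl in place of methylsulfanyl on an aromatic carbon. The same change has already been seen once, between compound 1 and compound 2, where the result was a 28-fold lower number from compound 1 to compound 2 (1.44 log units; beyond the scatter). That earlier step is the only one in this set that bears directly on the move from compound 3 to compound 4, and it was large and clearly beyond the scatter. A step of similar size and the same direction is therefore expected here, namely a 27-fold lower number from compound 3 to compound 4 (1.43 log units; beyond the scatter).

On that basis compound 4 is estimated at 5.5 nM, with a likely range from 2 nM to 16 nM.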

Compound 4, inhibition constant: 5.7 nM
Compound 4: the middle estimate sits 1.0-fold (0.02 log units) below what was measured; the range from low to high includes it.
By their numbers in this assay, from the lowest: compound 2; then compound 4; then compound 1; then compound 3.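

Putting phenyl in place of methylsulfanyl, on an aromatic carbon ortho to a large group, gives a 26-fold lower number from compound 3 to compound 4 (1.41 log units; beyond the scatter). The gain in this assay is therefore no longer a single observation, and it does not depend on the unsubstituted benzyl end of compound 1, since the change has now been seen on two cores, and the two steps agree: the same change on two cores in this assay, a 28-fold lower number (1.44 log units; beyond the scatter) from compound 1 to compound 2 and a 26-fold lower number (1.41 log units; beyond the scatter) from compound 3 to compound 4, 1.1-fold (0.02 log units) apart, within the scatter of two such steps. Read the other way, adding (methylsulfonyl)oxy costs about as much on the phenyl-bearing compounds as on the methylsulfanyl-bearing ones, with a 7.1-fold higher number from compound 2 to compound 4 (0.85 log units; beyond the scatter) and a close match between the two steps: the same change on two cores in this assay, a 6.7-fold higher number (0.83 log units; beyond the scatter) from compound 1 to compound 3 and a 7.1-fold higher number (0.85 log units; beyond the scatter) from compound 2 to compound 4, 1.1-fold (0.02 log units) apart, within the scatter of two such steps.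

Across these four compounds, then, the two changes behave independently, each shifting the number by much the same amount whichever group sits at the other end of the molecule. The compounds shown leave open whether another group at this position, such as methoxy or cyclohexyl, would follow the phenyl or the methylsulfanyl result, and whether the same independence would survive a shorter chain linking the two ends.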